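The source may hold more compounds than are shown below. What is called first, only, known or untested is meant among the compounds shown, and "the series" means these compounds.

Of the compounds shown here, three built on one shared core have been tested in a functional assay on the whole organism (blood) with Rattus norvegicus as the target, with stated times of 24 h and 1 h, at a dose of 5 mg/kg by the intraperitoneal route; a lower number here means a weaker effect, a higher number a stronger effect of the compound at the dose given. Compound 1 `COc1ccc(Cl)cc1C(=O)NCCC1CCN(S(=O)(=O)NC(=O)NC[C@H]2C[C@@H]3CC[C@@H]2O3)CC1` gives 27%. Compound 2 `CCCNC(=O)NS(=O)(=O)N1CCC(CCNC(=O)c2cc(C(F)(F)F)nn2C)CC1` gives 11%. Compound 3 `Cc1ncsc1C(=O)NCCC1CCN(S(=O)(=O)NC(=O)NC[C@@H]2C[C@@H]3C=C[C@@H]2C3)CC1` gives 11%, level with compound 2 at the digits shown, and the two together stand lowest of the three; compound 1 sits higher by an amount beyond the usual scatter. Compound 4 `O=C(NC[C@@H]1C[C@@H]2C=C[C@@H]1C2)NS(=O)(=O)N1CCC(CCNC(=O)c2nc3ccccc3s2)CC1` has not yet been measured. It differs from compound 3 in one place only: 1,3-benzothiazol-2-yl in place of 4-methyl-1,3-thiazol-5-yl on a carbonyl carbon. Among the compounds with values here, no pair of measured compounds differs by just this exchange, so there is no measured step from which a size could be read. Compound 1 with 27% shows that another group on the carbonyl carbon can go with a higher number, but that group is a different one. The step of a number 6 percentage points higher from compound 3 to compound 4 (within the scatter) is expected to be small, upward if anything, and not clearly beyond the scatter. Compound 4 is therefore expected to give about 17%, within a range from 5% to 32%.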

Compound 4, a percentage reported as activity, at one dose (the size of the read-out at that dose, not a potency): 24%
Compound 4: the middle estimate sits 7 percentage points below what was measured; the range from low to high includes it.
By their numbers in this assay, from the lowest: compounds 2 and 3 (each within the scatter of the next); then compounds 4 and 1 (each within the scatter of the next).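

In this assay, putting 1,3-benzothiazol-2-yl in place of 4-methyl-1,3-thiazol-5-yl on the carbonyl carbon gives a number 13 percentage points higher from compound 3 to compound 4 (beyond the scatter), the first measured size for a change at this position. The rest of the structure is the same in both compounds, so this position alone can move the read-out by more than the usual scatter at this dose. No measurement shown explains the rise.

The exchange alters two things at once, the attachment point on the five-membered ring and the presence of the six-membered aromatic ring of carbon only, and the compounds shown cannot separate them. A plain 1,3-thiazol-2-yl group or a phenyl group on the same carbonyl carbon would help to show which of the two goes with the higher number.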